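Swapping trifluoromethyl for methyl on an oxime ether

The source may hold more compounds than are shown below. What is called first, only, known or untested is meant among the compounds shown, and "the series" means these compounds.

Measured compounds:
- compound 1 `Cc1c(CO/N=C/c2c(-c3ccccc3)nn(-c3ccccc3)c2Oc2ccc(Cl)cc2)cccc1-c1ccccc1`: -17.5%
- compound 2 `Cc1nn(C)c(Oc2ccccc2)c1/C=N/OCc1ccc(C(F)(F)F)cc1`: 30.5%
- compound 3 `Cc1nn(C)c(Oc2ccc(Cl)cc2)c1/C=N/OCc1ccc([N+](=O)[O-])cc1`: 27.1%

In a functional assay on MCF7 cells (Homo sapiens) for antiproliferative activity, tested at 1 uM (a lower number here means less inhibition, a higher number more inhibition at the concentration tested (going by the name of the read-out)), compound 2 gives 30.5%, the highest of the three numbers. Compound 3 sits within the usual scatter of compound 2, so the two cannot be told apart. Compound 1, which carries several extra phenyl rings around the shared core, gives -17.5%, a number far below compound 2 and beyond the scatter.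

Compound 4 `Cc1ccc(CO/N=C/c2c(C)nn(C)c2Oc2ccccc2)cc1` is not yet measured. It differs from compound 2 in one place: methyl in place of trifluoromethyl on an aromatic carbon. The change sits on an aromatic carbon of a six-membered aromatic ring of carbon only, para to a large group.

Going by the values given here, no measured pair shows a step of this kind here, so the size of the effect is open. The step from compound 2 to compound 4 in this assay is expected to be small, most likely a modest drop or nothing beyond the scatter, so a number 7.5 percentage points lower from compound 2 to compound 4 (within the scatter) is the estimate. For compound 4 the expected value is 23%, with a range from 2% to 42%.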

Compound 4, a percentage reported as inhibition, at one concentration (the size of the read-out at that concentration, not a potency): 38.2%
For compound 4 the middle estimate is 15.2 percentage points below the measured one; the measured number falls inside the stated range.
By their numbers in this assay, from the lowest: compound 1; then compounds 3, 2 and 4 (each within the scatter of the next, the first and the last beyond it).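

In this assay, going by these compounds alone, this is the first pair of compounds that differ in one place, so the change can be read directly: methyl in place of trifluoromethyl gives a number 7.7 percentage points higher from compound 2 to compound 4 (within the scatter) and so does not separate the two compounds. Within the data shown here, removing the three fluorine atoms and leaving a single carbon on this aromatic carbon therefore produces no step that can be told from the usual scatter at this one concentration. Nothing measured here shows why the two groups give such similar results.

On these data alone, whether an amine, a carboxylic acid or a longer chain on the same carbon would also leave the number within the scatter remains open. One pair also cannot show whether this swap would behave the same way on a different core, such as that of compound 1.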